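The compounds below may be only part of what the source reports. "The series", "measured", "known", "first", "only" and "open" are said of these compounds alone.

Measured compounds:
- Compound 1, `COc1ccc(-c2c(S(=O)(=O)c3cccc(C#N)c3)cnc3cc(F)ccc23)cc1`: 0.92 mL/min
- Compound 2, `COc1cccc(S(=O)(=O)c2cnc3cc(F)ccc3c2-c2cccc(Cl)c2)c1`: 2.97 mL/min
- Compound 3, `COc1ccc(-c2c(S(=O)(=O)c3cccc(F)c3)cnc3cc(F)ccc23)cc1`: 1.89 mL/min

In an ADME assay on microsomes from liver (Homo sapiens) for metabolic stability, tested at 2.5 uM (on this read-out higher numbers stand for fast clearance and lower numbers for slow clearance), compound 3 stands second highest of the three numbers; compound 2 lies within the scatter of it, while compound 1 lies beyond the scatter, lower. Among the measured compounds shown here, the only single-point step among the measured compounds is a 2.1-fold higher number from compound 1 to compound 3 (0.31 log units; beyond the scatter), a modest rise.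

Compound 4, `COc1ccc(-c2c(S(=O)(=O)c3ccc(OC)cc3)cnc3cc(F)ccc23)cc1`, is not yet measured. It differs from compound 3 in one place: 4-methoxyphenyl in place of 3-fluorophenyl on a sulfonyl sulfur

For the measured compounds named here, no measured step covers this kind of change. The step from compound 1 to compound 3 concerns a different group and so gives no direct guide. Compound 2 also carries a methoxyphenyl on its sulfonyl sulfur, but it differs from compound 3 in two places, so only its own value can be noted: in this assay compound 2 gives 2.97 mL/min, a number within the scatter of compound 3. Taken together, the data leave room for a small rise or no change beyond the scatter.

The expected step is a 1.3-fold higher number from compound 3 to compound 4 (0.12 log units; within the scatter). Compound 4 is therefore estimated to give 2.5 mL/min in this assay, with a likely range from 1.2 mL/min to 5 mL/min.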

Compound 4, intrinsic clearance in a liver preparation (reported as CLH), per the amount of preparation that the assay uses: 1.18 mL/min
Compound 4: the middle estimate sits 2.1-fold (0.33 log units) above what was measured; measured number outside the range, below it.
By their numbers in this assay, from the lowest: compounds 1, 4, 3 and 2 (each within the scatter of the next, the first and the last beyond it).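

In this assay, among the compounds shown here, the first direct look at 4-methoxyphenyl on a sulfonyl sulfur gives a 1.6-fold lower number from compound 3 to compound 4 (0.20 log units; within the scatter) when it replaces 3-fluorophenyl, and a 1.3-fold higher number from compound 1 to compound 4 (0.11 log units; within the scatter) when it replaces 3-cyanophenyl. Compound 1 and compound 3 themselves lie apart, with a 2.1-fold higher number from compound 1 to compound 3 (0.31 log units; beyond the scatter), yet compound 4 lies within the scatter of both, so this position can hold a group with one more heavy atom and one hydrogen-bond acceptor without a clear shift in the read-out from either neighbour. No measurement shown here offers an explanation for these numbers.

For the compounds shown here, what remains open is whether the methoxy group itself or its place on the ring matters more, as no pair of compounds here changes one while keeping the other fixed. The compounds also leave open how this position would respond to a quite different group on the ring, such as an amine or a carboxylic acid, or to a longer chain in place of the ring.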